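This account rests on a few compounds, and the source may have more. Where it says the series, first, only, none or still open, it means among the compounds named here.

Series notes. Compound 1 `O=C(CSc1nc(Nc2ccccc2)c2ccccc2n1)Nc1ccccc1Br` gives 10300 nM in a functional assay on NCI-H1975 cells (Homo sapiens) for inhibition, read by MTT assay, with a stated time of 72 h; on this read-out higher numbers stand for weaker inhibition and lower numbers for stronger inhibition; compound 2 `CCc1cccc(NC(=O)CSc2nc(Nc3ccccc3)c3ccccc3n2)c1` gives 12000 nM; compound 3 `COc1cccc(NC(=O)CSc2nc(Nc3ccccc3)c3ccccc3n2)c1` gives 19400 nM and so holds the highest of the three numbers, though its steps to both others stay within the scatter: a 1.9-fold higher number from compound 1 to compound 3 (0.27 log units; within the scatter) and a 1.6-fold higher number from compound 2 to compound 3 (0.21 log units; within the scatter). Next comes compound 4 `O=C(CSc1nc(Nc2ccccc2)c2ccccc2n1)Nc1ccc(Cl)cc1Cl`, which differs from compound 3 as 2,4-dichlorophenyl in place of 3-methoxyphenyl on an amide-type nitrogen. The measured step that bears most on this is a 1.9-fold higher number from compound 1 to compound 3 (0.27 log units; within the scatter), since compound 1 carries 2-bromophenyl on the same amide-type nitrogen; a 1.6-fold higher number from compound 2 to compound 3 (0.21 log units; within the scatter) is likewise small. Every exchange on that nitrogen seen so far has stayed within the scatter, so no step beyond it is expected in this assay. Compound 4 is therefore estimated at 12000 nM, with a range of 5000 nM to 30000 nM. This estimate means an expected 1.6-fold lower number from compound 3 to compound 4 (0.21 log units; within the scatter).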

Compound 4, half-maximal inhibitory concentration: 8410 nM
Beside the measured number, compound 4's estimate is 1.4-fold (0.15 log units) above it, within the range that was stated.
By their numbers in this assay, from the lowest: compounds 4, 1, 2 and 3 (each within the scatter of the next, the first and the last beyond it).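

On the amide-type nitrogen, 2,4-dichlorophenyl in place of 3-methoxyphenyl is the only exchange shown that goes beyond the scatter in this assay (a 2.3-fold lower number from compound 3 to compound 4 (0.36 log units; beyond the scatter)). The same group in place of 3-ethylphenyl (a 1.4-fold lower number from compound 2 to compound 4 (0.15 log units; within the scatter)) or 2-bromophenyl (a 1.2-fold lower number from compound 1 to compound 4 (0.09 log units; within the scatter)) stays within it, so the change at this position rests on a single pair. Nothing available bears on the cause of that step. Open, on these data alone, is whether an amine or a carboxylic acid on the aromatic ring at this nitrogen would shift the number beyond the scatter. Exchanges elsewhere on the shared core also remain open.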